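Compound 1 to compound 4: an aryl exchange

A few compounds are considered here, and "the series" means these few. Any claim that something is new, unique, unknown or untested is made for them only; others in the source may bear on it.

Values in a functional assay on Vero cells (Chlorocebus sabaeus) for cytotoxicity, read by MTT assay; on this read-out lower numbers stand for higher toxicity in this test and higher numbers for lower toxicity in this test
- compound 1 `O=C(NCN1CCN(c2cccc(Cl)c2)CC1)c1cnccn1` gives "not determined" (no result reported)
- compound 2 `COc1c(N2CCN(CNC(=O)c3cnccn3)CC2)c(F)cc2c(=O)c(C(=O)O)cn(C3CC3)c12` gives > 62.5 ug/mL
- compound 3 `O=C(NCN1CCN(c2cc3c(cc2F)c(=O)c(C(=O)O)cn3C2CC2)CC1)c1cnccn1` gives > 62.5 ug/mL

Compound 1 has "not determined" (no result reported) as its entry in this assay, so it offers no number to start from. For compound 2 the entry > 62.5 ug/mL is a limit and not a number. For compound 3 the entry > 62.5 ug/mL is also a limit and not a number. The series thus stands at the limit of > 62.5 ug/mL in this assay, at which 2 of the 3 values shown sit, and nowhere else.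

Compound 4 `O=C(NCN1CCN(c2ccc(F)cc2)CC1)c1cnccn1` differs from compound 1 by 4-fluorophenyl in place of 3-chlorophenyl on an amine nitrogen in a ring and nothing more. For the measured compounds named here, the only measured step is a step that the two limits leave unreadable from compound 2 to compound 3 and it concerns hydrogen in place of methoxy on an aromatic carbon, not this exchange. No size or direction of step can therefore be expected in this assay for this change. The estimate rests on the limits alone, and a report of compound 4 as a limit would be no surprise. Compound 4 is expected at 80 ug/mL as an estimated value, within an expected range from 30 ug/mL to 200 ug/mL for the measurement.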

Compound 4, half-maximal cytotoxic concentration: > 62.5 ug/mL
Compound 4 gave a limit, no number; the forecaster's own chance of this, stated with the estimate: 70%; the middle value is on the limit's open side.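

In this assay compound 4 gives > 62.5 ug/mL, which is a limit and not a number. Compound 1 offers no number, so no step can be read from compound 1 to compound 4. The compounds shown leave open the size and direction of any effect of 4-fluorophenyl in place of 3-chlorophenyl, and the values cluster at a single limit: the limit of > 62.5 ug/mL in this assay, at which 3 of the 4 values shown sit.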